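Ester Variation on a Pyrazole Series Held at the Limit

A few compounds are considered here, and "the series" means these few. Any claim that something is new, unique, unknown or untested is made for them only; others in the source may bear on it.

Compound 3 `CC(C)c1cccc(OC(=O)c2cn(-c3ccccc3)nc2-c2cccnc2)c1` gives only a limit in a functional assay on MDA-MB-231 cells (Homo sapiens) for cytotoxicity, read by MTT assay, with a stated time of 48 h (a lower number here means a stronger inhibitor, a higher number a weaker inhibitor), namely > 100000 nM. Compound 1 `O=C(c1cn(-c2ccccc2)nc1-c1cccnc1)N1CCC(Cc2ccccc2)CC1` likewise gives a limit of > 100000 nM. Compound 2 `COc1ccc(OC(=O)c2cn(-c3ccccc3)nc2-c2cccnc2)cc1` also gives a limit, > 100000 nM. Among the compounds with values here, the single step between measured compounds, a step that the two limits leave unreadable from compound 2 to compound 3, cannot be read because all values sit at the limit (the limit of > 100000 nM in this assay, at which 3 of the 3 values shown sit). Compound 3 thus stands at the limit together with the other two, with no number of its own. Compound 4 `Cc1ccc(C(C)C)c(OC(=O)c2cn(-c3ccccc3)nc2-c2cccnc2)c1` differs from compound 3 by 2-isopropyl-5-methylphenyl in place of 3-isopropylphenyl on an oxygen next to a carbonyl group. No measured step bears on this change, since nothing shown is a number. Compound 4 is expected to show a step that the limit leaves unreadable from compound 3 to compound 4, that is, no step beyond the scatter. The estimate for compound 4 is 150000 nM, in a range from 50000 nM to 500000 nM.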

Compound 4, half-maximal inhibitory concentration: > 100000 nM
Compound 4: a limit, no number; the forecaster's own chance of this, stated with the estimate: 85%; the middle value lies beyond the limit too.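

Compound 4 stands at the limit with compound 2 and compound 3, so the steps to compound 4 cannot be read: the limit of > 100000 nM in this assay, at which 4 of the 4 values shown sit. The compounds shown leave open what value in this assay any of these esters would actually reach.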